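This account rests on a few compounds, and the source may have more. Where it says the series, first, only, none or still open, it means among the compounds named here.

Measured compounds:
compound 1 `O=S(=O)(NCCCCNCc1ccc(Br)cc1)c1cc(C(F)(F)F)cc(C(F)(F)F)c1`, 1600 nM
compound 2 `O=S(=O)(NCCCNCc1cccc2ccccc12)c1cc(C(F)(F)F)cc(C(F)(F)F)c1`, 2600 nM
compound 3 `COc1ccc(CNCCCNS(=O)(=O)c2cc(C(F)(F)F)cc(C(F)(F)F)c2)cc1`, 2900 nM

All three share the same sulfonamide core and were tested in a functional assay on HT-29 cells (Homo sapiens) for inhibition, read by MTT assay, with a stated time of 72 h; a lower number here means a stronger inhibitor of growth, a higher number a weaker inhibitor of growth. Compound 1 gives the lowest of the three numbers, but its nearest neighbour compound 2 and its furthest neighbour compound 3 both lie within the scatter of it, so no order among them can be claimed.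

Compound 4 `O=S(=O)(NCCCNCc1ccc(Cl)cc1)c1cc(C(F)(F)F)cc(C(F)(F)F)c1` has not yet been measured in this assay. It differs from compound 1 in one place: (4-chlorobenzyl)amino in place of ((4-bromobenzyl)amino)methyl on a saturated chain carbon, three bonds along the chain from a sulfonamide nitrogen.

Within the data shown here, two measured steps bear on this change. The step of a 1.8-fold higher number from compound 1 to compound 3 (0.26 log units; within the scatter) also replaces the ((4-bromobenzyl)amino)methyl group with a shorter benzylamino group carrying a different 4-substituent, and it stayed within the scatter. The step of a 1.1-fold higher number from compound 2 to compound 3 (0.05 log units; within the scatter) swaps one aryl group for another at the amine carbon and likewise stayed within the scatter. Neither step suggests that the shorter chain or the change of halogen moves the number beyond the scatter in either direction.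

Compound 4 is therefore expected to give about 2000 nM in this assay, with a likely range from 1000 nM to 4000 nM, which would mean a step of a 1.3-fold higher number from compound 1 to compound 4 (0.10 log units; within the scatter) and no change beyond the scatter.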

Compound 4, concentration for 50% growth inhibition: 2800 nM
For compound 4 the middle estimate is 1.4-fold (0.15 log units) below the measured one, within the range that was stated.
By their numbers in this assay, from the lowest: compounds 1, 2, 4 and 3 (each within the scatter of the next).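

In this assay, the change to (4-chlorobenzyl)amino gives a 1.8-fold higher number from compound 1 to compound 4 (0.24 log units; within the scatter) and so shows directly that replacing ((4-bromobenzyl)amino)methyl at this place, which alters the chain and the halogen together, leaves the number within the scatter. The new chloro group also gives the series a second and third comparison among the aromatic groups: chloro in place of methoxy on an aromatic carbon gives a 1.0-fold lower number from compound 3 to compound 4 (0.02 log units; within the scatter) and 4-chlorophenyl in place of naphthalen-1-yl gives a 1.1-fold higher number from compound 2 to compound 4 (0.03 log units; within the scatter) and thus 4-chlorophenyl, 4-methoxyphenyl and naphthalen-1-yl cannot be told apart in this assay on the chain they share. No measurement shown accounts for how close these numbers lie.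

The step between the 4-bromobenzyl and 4-chlorobenzyl compounds cannot be divided between chain and halogen, and a 4-chlorobenzyl group on the longer chain would be needed to separate the two. As far as these compounds go, it also remains open whether a carboxylic acid on the aromatic ring, or an amide in place of the amine, would move the number beyond the scatter.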